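This account rests on a few compounds, and the source may have more. Where it says the series, first, only, none or still open, it means among the compounds named here.

In a functional assay on HCC 2998 cells (Homo sapiens) for antiproliferative activity (a lower number here means a stronger inhibitor of growth, a higher number a weaker inhibitor of growth), the measured compounds are:
- compound 1 `COc1ccc(-c2nc3cc(F)ccc3s2)cc1OC` with 0.25 nM as its value
- compound 2 `COc1cc(-c2nc3cc(F)ccc3s2)cc(OC)c1OC` with 21100 nM as its value

Compound 1 has the lower of these two numbers. Compound 3 `COc1ccc(-c2nc3cc(F)ccc3s2)c(OC)c1OC` has not been measured yet. It differs from compound 1 by methoxy in place of hydrogen on an aromatic carbon and keeps the shared core. Among the measured compounds shown here, only one measured step bears on this: the same kind of swap, on a different aromatic carbon, gave an 84000-fold higher number from compound 1 to compound 2 (4.93 log units; beyond the scatter) and is large. One step is thin evidence, so a large move to a higher number is expected, though probably a smaller one. The expected step is a 4000-fold higher number from compound 1 to compound 3 (3.60 log units; beyond the scatter) as an estimate. For compound 3 the estimated value is 1000 nM (expected range 10 nM to 50000 nM).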

Compound 3, concentration for 50% growth inhibition: 37 nM
The estimate for compound 3 lay 27-fold (1.43 log units) above the measured number; the measured number falls inside the stated range.
By their numbers in this assay, from the lowest: compound 1; then compound 3; then compound 2.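

Placing methoxy on this aromatic carbon, ortho to a large group, also weakens growth inhibition in this assay (a 150-fold higher number from compound 1 to compound 3 (2.17 log units; beyond the scatter)). This large step is still smaller than the one at the other aromatic carbon (an 84000-fold higher number from compound 1 to compound 2 (4.93 log units; beyond the scatter)), so the size of the loss depends on where the added methoxy sits. Nothing shown here explains this difference between the two positions.

On these data alone, it remains open whether a hydroxyl or an amine in place of this hydrogen would also raise the number, or whether a longer ether chain would raise it further.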